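Methyl for hydroxy at the benzimidazole end, series notes

A few compounds are considered here, and "the series" means these few. Any claim that something is new, unique, unknown or untested is made for them only; others in the source may bear on it.

Growth inhibition in a functional assay on DWD cells (Homo sapiens) for inhibition, read by sulforhodamine B assay; a lower number here means a stronger inhibitor of growth, a higher number a weaker inhibitor of growth:
- compound 1 `Cc1ccc2[nH]c(-c3ccc(-c4ccc(-c5ccc(N(C)C)cc5)cc4)cc3)nc2c1`: 3230 nM
- compound 2 `FC(F)(F)Oc1ccc(-c2ccc(-c3ccc(-c4nc5ccccc5[nH]4)cc3)cc2)cc1`: 100000 nM
- compound 3 `Oc1cccc2[nH]c(-c3ccc(-c4ccc(-c5ccc(OC(F)(F)F)cc5)cc4)cc3)nc12`: 3100 nM
- compound 4 `Cc1ccc2[nH]c(-c3ccc(-c4ccc(-c5ccc(OC(F)(F)F)cc5)cc4)cc3)nc2c1`: not yet measured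

Compound 3 gives 3100 nM, within the scatter of compound 1 at 3230 nM. Among the compounds with values here, the only measured single-site step is a 32-fold lower number from compound 2 to compound 3 (1.51 log units; beyond the scatter), with hydroxy in place of hydrogen on an aromatic carbon, and it is large.

The next change is 5-methyl-1H-benzimidazol-2-yl in place of 4-hydroxy-1H-benzimidazol-2-yl on an aromatic carbon: 5-methyl-1H-benzimidazol-2-yl in place of 4-hydroxy-1H-benzimidazol-2-yl, para to a large group. This removes the hydroxy, so a 32-fold lower number from compound 2 to compound 3 (1.51 log units; beyond the scatter) bears on it, read in reverse. Within the data shown here, no measured step isolates the methyl. Compound 1 carries the same 5-methyl-1H-benzimidazol-2-yl and gives 3230 nM, but it differs elsewhere, so it offers only weak support for a partial recovery.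

The expected step is a 3.9-fold higher number from compound 3 to compound 4 (0.59 log units; beyond the scatter), towards a higher number in this assay, smaller than the measured one but beyond the scatter. The estimate for compound 4 is 12000 nM, with an expected range of 2500 nM to 60000 nM.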

Compound 4, concentration for 50% growth inhibition: 41100 nM
Compound 4: the middle estimate sits 3.4-fold (0.53 log units) below what was measured; the range from low to high includes it.
By their numbers in this assay, from the lowest: compounds 3 and 1 (each within the scatter of the next); then compound 4; then compound 2.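

In this assay, the methyl recovers only a small part of what the hydroxy gains: a 2.4-fold lower number from compound 2 to compound 4 (0.39 log units; beyond the scatter), whereas a 13-fold higher number from compound 3 to compound 4 (1.12 log units; beyond the scatter), so 5-methyl-1H-benzimidazol-2-yl is no match for 4-hydroxy-1H-benzimidazol-2-yl in the trifluoromethoxy compounds. With 5-methyl-1H-benzimidazol-2-yl held fixed, the group at the far end also counts, with a 13-fold higher number from compound 1 to compound 4 (1.10 log units; beyond the scatter), a large step for trifluoromethoxy in place of dimethylamino. No measurement at hand gives a reason for any of these steps.

Going by these compounds, whether the gain is particular to the hydroxy, or would also come with a methoxy group or an amine on the same ring, stays open. Also open, on these data alone, is whether the hydroxy and the dimethylamino group would add up in a single compound.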